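This account rests on a few compounds, and the source may have more. Where it says the series, first, only, none or still open, it means among the compounds named here.

Measured in an assay on CHO-K1 cells for displacement of a labelled ligand from prostaglandin E2 receptor EP1 subtype (Homo sapiens); a lower number here means a stronger inhibitor, a higher number a weaker inhibitor:
compound 1 `Cc1cc(C(=O)Nc2ccccc2)nn1Cc1cc(Cl)ccc1OCc1ccccc1`, 39.8 nM
compound 2 `Cc1cc(NC(=O)C(C)C)nn1Cc1cc(Cl)ccc1OCc1ccccc1`, 25.1 nM
compound 3 `Cc1cc(NC(=O)C2CCCC2)nn1Cc1cc(Cl)ccc1OCc1ccccc1`, 15.9 nM

For the measured compounds named here, compound 3 has the lowest number of the three, but its gap to compound 2 is within the scatter; only the step of a 2.5-fold lower number from compound 1 to compound 3 (0.40 log units; beyond the scatter) lies beyond it. Compound 4 `Cc1cc(NC(=O)c2c(F)cccc2F)nn1Cc1cc(Cl)ccc1OCc1ccccc1` differs from compound 3 by 2,6-difluorophenyl in place of cyclopentyl on a carbonyl carbon. Going by the values given here, no measured step exchanges a ring of this kind on the carbonyl carbon; the nearest is a 1.6-fold lower number from compound 2 to compound 3 (0.20 log units; within the scatter), a small change, and the one compound whose amide carries a phenyl group, compound 1, gives 39.8 nM, the highest number here. A small rise is therefore expected, with the expected step being a 1.6-fold higher number from compound 3 to compound 4 (0.20 log units; within the scatter). Compound 4 is estimated at 25 nM, within a range from 8 nM to 80 nM.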

Compound 4, half-maximal inhibitory concentration: 12.6 nM
Compound 4: middle estimate off by 2.0-fold (0.30 log units), on the high side; low and high end bracket the measured number.
By their numbers in this assay, from the lowest: compounds 4, 3, 2 and 1 (each within the scatter of the next, the first and the last beyond it).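

On this carbonyl carbon, an aromatic ring with two fluorines holds up as well as a saturated ring in this assay: a 1.3-fold lower number from compound 3 to compound 4 (0.10 log units; within the scatter). The same holds against the smaller isopropyl group, with a 2.0-fold lower number from compound 2 to compound 4 (0.30 log units; within the scatter), so size and ring type have shown no clear effect at this position so far. Only a 3.2-fold lower number from compound 1 to compound 4 (0.50 log units; beyond the scatter) lies beyond the scatter, so the high number of compound 1 cannot be charged to an aromatic ring alone.

Nothing available explains why this exchange moves the number so little. On these data alone, whether a plain phenyl without the fluorines, or a carboxylic acid or an amine on the acyl group, would fit equally well remains open.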